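The compounds below may be only part of what the source reports. "The series", "measured", "known", "first", "only" and "open" are said of these compounds alone.

Compound 1 `CCCSc1nc(Cl)c2c(n1)N(Cc1ccccc1)C(C(=O)OCC)N2` is the reference point here; in a functional assay on MGC-803 cells (Homo sapiens) for antiproliferative activity, read by MTT assay, with a stated time of 72 h (on this read-out lower numbers stand for stronger inhibition and higher numbers for weaker inhibition), compound 1 gives 18500 nM. Compound 3 `CCCSc1nc(Cl)c2c(n1)N(Cc1ccccc1)C(C(=O)Nc1ccccc1)N2` carries an anilino group in place of the ethoxy on the carbonyl carbon, and in this assay compound 3 gives 58400 nM, which amounts to a 3.2-fold higher number from compound 1 to compound 3 (0.50 log units; beyond the scatter). Compound 2 `CCCSc1nc(Cl)c2c(n1)N(Cc1ccccc1)C(C(=O)NCCNC(=O)OC(C)(C)C)N2` carries a (2-((tert-butoxycarbonyl)amino)ethyl)amino group on that same carbonyl carbon. In this assay compound 2 reaches only a limit of the assay, > 64000 nM. For compound 2 this is the limit of > 64000 nM in this assay, at which 1 of the 3 values shown sits. Compound 2 therefore has no number of its own, only a floor, and from it there is an at least 3.4-fold higher number from compound 1 to compound 2 (0.53 log units; beyond the scatter), while the comparison of the two amide-type compounds shows an at least 1.0-fold lower number from compound 2 to compound 3 (0.03 log units; that floor lies within the scatter). Compound 4 `CCCSc1nc(Cl)c2c(n1)N(Cc1ccccc1)C(C(=O)N1CCN(C)CC1)N2` has not yet been measured; it differs from compound 2 in one place: 4-methylpiperazin-1-yl in place of (2-((tert-butoxycarbonyl)amino)ethyl)amino on a carbonyl carbon. The two changes that bear on this step are the two replacements of the ethoxy by an amide-type nitrogen, each of which raised the number by a modest amount, and the two resulting compounds sit close to each other. A third amide-type compound is expected to land in the same region, so for compound 4 the estimate is 55000 nM, within 20000 nM to 150000 nM, which corresponds to an expected at least 1.1-fold lower number from compound 2 to compound 4 (0.06 log units; that floor lies within the scatter).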

Compound 4, half-maximal inhibitory concentration: > 64000 nM
Compound 4 ended at the assay's limit (the forecaster's own chance of this, stated with the estimate: 40%); middle value at least 1.1-fold (0.06 log units) away from the limit.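

In this assay, putting 4-methylpiperazin-1-yl in place of the ethoxy on the carbonyl carbon gives an at least 3.4-fold higher number from compound 1 to compound 4 (0.53 log units; beyond the scatter), so all three amide-type groups shown now go the same way, including this one with a six-membered ring and no hydrogen-bond donors. Against the anilino group, the result gives only an at least 1.0-fold higher number from compound 3 to compound 4 (0.03 log units; that floor lies within the scatter), so it does not rank 4-methylpiperazin-1-yl against anilino. Compound 2 and compound 4 each stand at a limit of the assay rather than at a number, and the step between them cannot be read: the limit of > 64000 nM in this assay, at which 2 of the 4 values shown sit.

From the compounds shown here alone, it remains open how weak compound 2 and compound 4 really are, and whether any group on this carbonyl carbon can give a lower number than the ethoxy of compound 1. A carboxylic acid, a methyl ester or an ester with a longer chain in this place would show whether the ester link alone keeps the number of compound 1 or whether the ethyl chain also matters.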